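A Bromo Group Enters the Anilino Ring

The source may hold more compounds than are shown below. What is called first, only, known or untested is meant among the compounds shown, and "the series" means these compounds.

The three measured compounds share one core and differ only on the anilino ring. Going by the values given here, in a functional assay on HT29-AK cells (Homo sapiens) for cytotoxicity, read by MTT assay, with a stated time of 48 h (a lower number here means a stronger inhibitor, a higher number a weaker inhibitor), compound 1 `Fc1cccc(-c2nc(Nc3ccccc3)c3cc(F)ccc3n2)c1` gives 48300 nM, the only plain number among the values shown. Compound 2 `Fc1ccc(Nc2nc(-c3cccc(F)c3)nc3ccc(F)cc23)cc1` gives > 50000 nM in this assay, which is a limit of the assay and not a number. Compound 3 `Fc1cccc(-c2nc(Nc3ccc(Br)cc3)c3cc(F)ccc3n2)c1` gives > 50000 nM in this assay, again a limit. Hence the step of an at least 1.0-fold higher number from compound 1 to compound 2 (0.01 log units; that floor lies within the scatter) and the step of an at least 1.0-fold higher number from compound 1 to compound 3 (0.01 log units; that floor lies within the scatter) can only be read as floors, and the step that the two limits leave unreadable from compound 2 to compound 3 cannot be read at all.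

Compound 4 `Fc1cccc(-c2nc(Nc3cccc(Br)c3)c3cc(F)ccc3n2)c1` differs from compound 1 by bromo in place of hydrogen on an aromatic carbon. The step that bears on it most closely is an at least 1.0-fold higher number from compound 1 to compound 3 (0.01 log units; that floor lies within the scatter), a bromo entering the same ring. Since the limit of > 50000 nM in this assay, at which 2 of the 3 values shown sit, covers two of three values, compound 4 is expected to sit near that limit as well, with a step of a 1.1-fold higher number from compound 1 to compound 4 (0.06 log units; within the scatter) that is not expected to exceed the scatter. Compound 4 is estimated at 55000 nM, within a range from 28000 nM to 110000 nM.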

Compound 4, half-maximal inhibitory concentration: > 50000 nM
Compound 4: a limit, no number; the forecaster's own chance of this, stated with the estimate: 65%; the middle value does not contradict the limit.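

With compound 4, a bromo stands at a second place on the anilino ring, on an aromatic carbon meta to a large group, and in this assay this compound again gives a limit, not a number. The step is an at least 1.0-fold higher number from compound 1 to compound 4 (0.01 log units; that floor lies within the scatter), so moving the bromo to this position still yields only a floor, one that lies within the scatter. The steps from compound 2 and from compound 3 to compound 4 cannot be read, which leaves the two bromo placements unordered, and the series now gathers at a single ceiling: the limit of > 50000 nM in this assay, at which 3 of the 4 values shown sit.

On these data alone, it remains open whether an amine or a carboxylic acid on the anilino ring would give a plain number lower than that of compound 1, 48300 nM. Also open, as far as these compounds go, is whether the 3-bromophenyl and 4-bromophenyl groups differ at all in this assay.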